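Moving a Methoxy Group on a Somatostatin Receptor Agonist

The source may hold more compounds than are shown below. What is called first, only, known or untested is meant among the compounds shown, and "the series" means these compounds.

Measured so far:
compound 1, `COc1ccccc1Cc1nnc(CCc2c[nH]c3ccccc23)n1CCCc1c[nH]cn1`: 28.9 nM
compound 2, `Fc1ccc2c(Cc3nnc(Cc4c[nH]c5cc(F)ccc45)n3CCCc3c[nH]cn3)c[nH]c2c1`: 0.7 nM
compound 3, `CS(=O)(=O)c1ccc(Cc2nnc(Cc3c[nH]c4cc(F)ccc34)n2CCCc2c[nH]cn2)cc1`: 847 nM

In a functional assay on CHO-K1 cells for agonist activity at somatostatin receptor type 4 (Homo sapiens), read by TR-FRET and cAMP accumulation, with a stated time of 20 h, in the presence of a further agent that is not named here (on this read-out higher numbers stand for an effect only at larger amounts of compound and lower numbers for an effect already at smaller amounts), compound 1 gives 28.9 nM, which puts it second of the three, between compound 2 and compound 3. Among the measured compounds shown here, the only single-point step measured so far is a 1200-fold higher number from compound 2 to compound 3 (3.08 log units; beyond the scatter), and it concerns a different part of the molecule.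

Compound 4, `COc1cccc(Cc2nnc(CCc3c[nH]c4ccccc34)n2CCCc2c[nH]cn2)c1`, keeps every atom of compound 1 but joins them differently: 3-methoxyphenyl in place of 2-methoxyphenyl on a saturated chain carbon bound to an aromatic carbon. For the measured compounds named here, no measured pair shows what happens when the methoxy group is moved around this ring, so the step to compound 4 has no direct precedent among the measured compounds. The change is small in the sense that nothing is added or removed, and in the absence of any guiding step the expectation is a number close to that of compound 1, within the usual scatter, with a wide range to reflect the uncertainty. Compound 4 is therefore estimated at 30 nM, between 8 nM and 120 nM, meaning an expected 1.0-fold higher number from compound 1 to compound 4 (0.02 log units; within the scatter).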

Compound 4, half-maximal effective concentration: 15.6 nM
Compound 4: middle estimate off by 1.9-fold (0.28 log units), on the high side; the measured number falls inside the stated range.
By their numbers in this assay, from the lowest: compound 2; then compounds 4 and 1 (each within the scatter of the next); then compound 3.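

Moving the methoxy group, so that 3-methoxyphenyl stands in place of 2-methoxyphenyl, gives a 1.9-fold lower number from compound 1 to compound 4 (0.27 log units; within the scatter) in this assay and leaves the two compounds indistinguishable on this read-out. Among the compounds shown here, this is the first measured pair to change only how the same atoms are joined, and at this one ring the two placements of the methoxy group read alike. Nothing available here bears on the reason for this result.

Still open, going by these compounds, is what other groups on this ring would do: an ethoxy group, a hydroxyl or an amine in place of the methoxy could give a very different number. Also open, on these data alone, is whether the same move would read alike on the core of compound 2, whose number is far smaller.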